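Swapping the aryl ether on a coumarin-linked pyrazole

The source may hold more compounds than are shown below. What is called first, only, known or untested is meant among the compounds shown, and "the series" means these compounds.

Within the data shown here, compound 2 `Cc1nn(C)c(Oc2cccc(Cl)c2)c1/C=N\CCCCCCOc1cc2oc(=O)cc(C)c2cc1Cl` is the only compound with a number in a functional assay on SMMC-7721 cells (Homo sapiens) for antiproliferative activity, read by MTT assay, with a stated time of 72 h (on this read-out lower numbers stand for stronger inhibition and higher numbers for weaker inhibition), where compound 2 gives 5260 nM. Compound 1 `Cc1nn(C)c(Oc2ccccc2F)c1/C=N\CCCCCCOc1cc2oc(=O)cc(C)c2cc1Cl` gives only a limit, > 25000 nM. Among the measured compounds shown here, the one measured step, an at least 4.7-fold lower number from compound 1 to compound 2 (0.67 log units; beyond the scatter), changed this same aryl ether. Compound 3 `Cc1ccccc1Oc1c(/C=N\CCCCCCOc2cc3oc(=O)cc(C)c3cc2Cl)c(C)nn1C` differs from compound 2 by 2-methylphenyl in place of 3-chlorophenyl on an oxygen on an aromatic ring. For the measured compounds named here, with only that single step to go on, and with the limit of > 25000 nM in this assay, at which 1 of the 2 values shown sits, on one side of it, a modest move toward weaker inhibition is expected, a 2.1-fold higher number from compound 2 to compound 3 (0.32 log units; beyond the scatter). Compound 3 is therefore estimated at 11000 nM, within a range of 3500 nM to 30000 nM.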

Compound 3, half-maximal inhibitory concentration: 5120 nM
Estimate against measurement, compound 3: 2.1-fold (0.33 log units) above; low and high end bracket the measured number.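

In this assay, 2-methylphenyl in place of 3-chlorophenyl shows no separation, a 1.0-fold lower number from compound 2 to compound 3 (0.01 log units; within the scatter), so on this oxygen two aryl groups with different substituents give matching results. Methyl in place of fluoro gives an at least 4.8-fold lower number from compound 1 to compound 3 (0.68 log units; beyond the scatter), making compound 1 the one that stands apart among the three. Compound 1 gives > 25000 nM, which is a limit of the assay and not a number. Still open, as far as these compounds go, is whether an aryl group carrying an amine or a carboxylic acid would stay near compound 2 and compound 3, or fall with compound 1.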